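The source may report more compounds than this note shows. Statements on the series, on what has been measured and on what is new or still open speak of the compounds shown alone.

Compound 1 `CCCN1CCN(c2ccc(S(=O)(=O)Oc3cccc(F)c3)cc2)C1=O`: 18000 nM
Compound 2 `CCCN1CCN(c2ccc(S(=O)(=O)Oc3cccc(Cl)c3)cc2)C1=O`: 13000 nM
Compound 3 `CCCN1CCN(c2ccc(S(=O)(=O)Oc3ccc(F)cc3)cc2)C1=O`: 23000 nM

All three were tested in a functional assay on HT-29 cells (Homo sapiens) for antiproliferative activity, read by sulforhodamine B assay, with a stated time of 48 h; a higher number here means a weaker inhibitor, a lower number a stronger inhibitor. One change, (chloro in place of fluoro on an aromatic carbon), made a 1.4-fold lower number from compound 1 to compound 2 (0.14 log units; within the scatter). Compound 3 has a different core, which differs from the core of compound 1 by 4-fluorophenyl in place of 3-fluorophenyl on an oxygen; this rearrangement gave a 1.3-fold higher number from compound 1 to compound 3 (0.11 log units; within the scatter). Compound 4 `CCCN1CCN(c2ccc(S(=O)(=O)Oc3ccc(Cl)cc3)cc2)C1=O` has not yet been measured; it differs from compound 3 by chloro in place of fluoro on an aromatic carbon. Among the measured compounds shown here, this is the same kind of change as the one between compound 1 and compound 2, but the place is not the same: there the group sits meta to a large group, here para to a large group. Because the earlier step was a 1.4-fold lower number from compound 1 to compound 2 (0.14 log units; within the scatter), a step of about a 1.4-fold lower number from compound 3 to compound 4 (0.16 log units; within the scatter) is expected, resting on that single pair alone. Compound 4 is therefore estimated at 16000 nM, with a range from 8000 nM to 35000 nM.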

Compound 4, half-maximal inhibitory concentration: 15000 nM
Compound 4: the middle estimate sits 1.1-fold (0.03 log units) above what was measured; the range from low to high includes it.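

In this assay, chloro in place of fluoro on the core of compound 3 gave a 1.5-fold lower number from compound 3 to compound 4 (0.19 log units; within the scatter), and this step agrees with the one on the core of compound 1: the same change on two cores in this assay, a 1.4-fold lower number (0.14 log units; within the scatter) from compound 1 to compound 2 and a 1.5-fold lower number (0.19 log units; within the scatter) from compound 3 to compound 4, 1.1-fold (0.04 log units) apart, within the scatter of two such steps The other two new steps, a 1.2-fold higher number from compound 2 to compound 4 (0.06 log units; within the scatter) and a 1.2-fold lower number from compound 1 to compound 4 (0.08 log units; within the scatter), also lie within the scatter. The change therefore carried across these two cores with no difference that can be told apart, but since each step is itself within the scatter, this does not show that chloro and fluoro differ here, and two pairs set no rule for other cores.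

On these data alone, it remains open whether a methoxy or nitrile group on the phenyl ring, or a butyl chain in place of the propyl chain, would give a step beyond the scatter.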